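The compounds below may be only part of what the source reports. "The series", "measured", "known", "first", "only" and "open" are said of these compounds alone.

Of the compounds shown here, three have been measured in an assay for binding affinity to 17-beta-hydroxysteroid dehydrogenase 14 (Homo sapiens), read by fluorescence, with a stated time of 15 min, in the presence of a further agent that is not named here; a lower number here means a stronger inhibitor, a higher number a weaker inhibitor. Compound 1 `Oc1cc(Oc2cccc(-c3cccc(O)c3F)n2)ccc1F` gives 58 nM, compound 2 `O=C(Nc1cccc(-c2cccc(O)c2F)n1)c1ccc(F)c(O)c1` gives 686 nM, and compound 3 `N#Cc1ccc2ccc(C(=O)c3ccc(F)c(O)c3)nc2c1` gives 9 nM. Compound 3 therefore holds the lowest number of the three, and its distance to both compound 1 and compound 2 lies beyond the usual scatter, so it is the strongest inhibitor among them in this assay. Compound 4 `O=C(c1ccc(F)c(O)c1)c1ccc2ccccc2n1` has not been measured yet. It differs from compound 3 in one place: hydrogen in place of cyano on an aromatic carbon of the fused two-ring part of the shared core. Among the measured compounds shown here, no measured pair shows what this exact change does, so the expectation for the step from compound 3 to compound 4 rests on the change alone; a modest rise in the number, or none beyond the scatter, seems most likely, as estimated by a 2.8-fold higher number from compound 3 to compound 4 (0.44 log units; beyond the scatter). On that basis compound 4 is expected to give about 25 nM in this assay, with a range from 8 nM to 80 nM.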

Compound 4, inhibition constant: 12 nM
Compound 4: the middle estimate sits 2.1-fold (0.32 log units) above what was measured; the measured number falls inside the stated range.
By their numbers in this assay, from the lowest: compounds 3 and 4 (each within the scatter of the next); then compound 1; then compound 2.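

In this assay, among the compounds shown here, hydrogen in place of cyano on this aromatic carbon of the fused two-ring part gives a 1.3-fold higher number from compound 3 to compound 4 (0.12 log units; within the scatter), the first view of this change on its own, as the earlier compounds differ from one another in more than one place. At this position, then, the low number of compound 3 does not depend on the cyano group: with that group's two heavy atoms and its hydrogen-bond acceptor gone, compound 4 stays within the scatter of compound 3. Nothing available here explains why the two numbers lie so close.

The compounds shown offer only hydrogen and cyano at this carbon, so what an amine, a carboxylic acid or a longer chain would do there stays open. They also leave open whether the same change would give so small a step at any other carbon of the fused two-ring part.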